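Compound 2 to compound 4: swapping the anilide group

The source may hold more compounds than are shown below. What is called first, only, known or untested is meant among the compounds shown, and "the series" means these compounds.

Compound 1 `Cc1ccc(NC(=O)C2CCN(C/C=C/c3ccccc3)CC2)cc1` gives 30000 nM in a functional assay on MCF7 cells (Homo sapiens) for inhibition, read by MTT assay, with a stated time of 72 h; on this read-out lower numbers stand for stronger inhibition and higher numbers for weaker inhibition
Compound 2 `CCCc1ccc(NC(=O)C2CCN(C/C=C/c3ccccc3)CC2)cc1` gives 9030 nM in this assay
Compound 3 `CCCCc1ccc(NC(=O)C2CCN(C/C=C/c3ccccc3)CC2)cc1` gives 5870 nM in this assay

Compound 2 stands clear of one measured neighbour and within the scatter of the other (a 3.3-fold lower number from compound 1 to compound 2 (0.52 log units; beyond the scatter); a 1.5-fold lower number from compound 2 to compound 3 (0.19 log units; within the scatter)). Compound 4 `O=C(Nc1cccc(Br)c1)C1CCN(C/C=C/c2ccccc2)CC1` carries 3-bromophenyl in place of 4-propylphenyl on an amide-type nitrogen. Going by the values given here, no measured step brings in bromine or moves a group, so the evidence is partial. The nearest guides are modest chain steps (a 3.3-fold lower number from compound 1 to compound 2 (0.52 log units; beyond the scatter); a 5.1-fold lower number from compound 1 to compound 3 (0.71 log units; beyond the scatter)). With the propyl chain leaving, a modest step towards a higher number is expected in this assay, back towards compound 1. The estimated step is a 2.2-fold higher number from compound 2 to compound 4 (0.35 log units; beyond the scatter) in this expectation. Compound 4 is estimated at 20000 nM with an expected range (7000 nM to 50000 nM).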

Compound 4, half-maximal inhibitory concentration: 11500 nM
Beside the measured number, compound 4's estimate is 1.7-fold (0.24 log units) above it; the range from low to high includes it.
By their numbers in this assay, from the lowest: compounds 3, 2 and 4 (each within the scatter of the next); then compound 1.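

In this assay, 3-bromophenyl on the amide-type nitrogen carries no alkyl chain, yet its number stays level with that of 4-propylphenyl (a 1.3-fold higher number from compound 2 to compound 4 (0.11 log units; within the scatter)). Going by these compounds alone, it also stands clear of 4-methylphenyl (a 2.6-fold lower number from compound 1 to compound 4 (0.42 log units; beyond the scatter)), so lengthening the chain is not the only change at this position that lowers the number. Nothing measured here accounts for this result.

The compounds shown do not separate the bromine from its place on the ring. On these data alone, how a chlorine, a methoxy group or an amine on that phenyl ring would read remains open.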